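The compounds below may be only part of what the source reports. "The series", "measured", "known", "first", "only" and "open" are said of these compounds alone.

Measured compounds and their values in an ADME assay on RAW264.7 cells (Mus musculus) for cytotoxicity, read by MTT assay, with a stated time of 24 h; a higher number here means that more compound is tolerated, a lower number that less compound is tolerated:
compound 1 `CC/C=C\CC1C(=O)C=CC1CC(=O)OC` gives 140 uM;
compound 2 `CC/C=C\C[C@H]1C(=O)C=C[C@H]1CC(=O)Oc1ccccc1` gives 158 uM;
compound 3 `CC/C=C\C[C@H]1C(=O)C=C[C@H]1CC(=O)Oc1ccccc1OC` gives 161 uM.

Compound 2 stands second highest of the three numbers in this assay, but its nearest neighbour compound 3 and its furthest neighbour compound 1 both lie within the scatter of it, so no order among the three can be claimed. The unmeasured compound 4 `CC/C=C\C[C@H]1C(=O)C=C[C@H]1CC(=O)OC(C)CC` differs from compound 2 in one place: sec-butyl in place of phenyl on an oxygen next to a carbonyl group.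

Within the data shown here, one measured step touches the same part of the molecule, the group on the ester oxygen. From compound 2 to compound 3 the result was a 1.0-fold higher number from compound 2 to compound 3 (0.01 log units; within the scatter). Compound 1, which carries a methyl group on that oxygen in place of the phenyl of compound 2, shows a number that also sits within the scatter of compound 2. On this basis the step to compound 4 in this assay is expected to be none beyond the scatter, that is a 1.1-fold lower number from compound 2 to compound 4 (0.02 log units; within the scatter). Compound 4 is therefore estimated at 150 uM, with a range from 90 uM to 250 uM.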

Compound 4, half-maximal toxic concentration: 53 uM
The estimate for compound 4 lay 2.8-fold (0.45 log units) above the measured number; the measured number lies below the stated range.
By their numbers in this assay, from the lowest: compound 4; then compounds 1, 2 and 3 (each within the scatter of the next).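

In this assay, among these compounds, the group on the ester oxygen proves able to move the number: sec-butyl in place of phenyl gives a 3.0-fold lower number from compound 2 to compound 4 (0.47 log units; beyond the scatter), the only step here that lies beyond the scatter. On the phenyl ring itself, methoxy in place of hydrogen gave only a 1.0-fold higher number from compound 2 to compound 3 (0.01 log units; within the scatter), so that step gave no sign of what replacing the whole phenyl group would do. Nothing available explains why this exchange lowers the number.

The compounds shown leave open whether the drop belongs to sec-butyl in particular or to the loss of the aromatic ring, a question that a straight butyl chain, a cyclohexyl group or a benzyl group on that oxygen would address. They also leave open whether an amine or a carboxylic acid on the phenyl ring of compound 2 would shift the number.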